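This account rests on a few compounds, and the source may have more. Where it says the series, first, only, none or still open, it means among the compounds named here.

Measured so far, in a functional assay on brain (Rattus norvegicus, strain Wistar) for inhibition; a lower number here means a stronger inhibitor, a higher number a weaker inhibitor: compound 1 `CCCCc1ccc(-c2c(C)[nH]c(=O)n2C2CCCCC2)cc1` gives 27100 nM; compound 2 `CCCCCc1ccc(-c2c(C)[nH]c(=O)n2C2CCCCC2)cc1` gives 10600 nM.

Compound 2 stands lowest of the two numbers, separated from compound 1 by the step of a 2.6-fold lower number from compound 1 to compound 2 (0.41 log units; beyond the scatter), modest but beyond the scatter. Compound 3 `CCCCCCCOc1ccc(-c2c(C)[nH]c(=O)n2C2CCCCC2)cc1` differs from compound 2 by heptyloxy in place of pentyl on an aromatic carbon. Among the compounds with values here, the only measured step that bears on this is a 2.6-fold lower number from compound 1 to compound 2 (0.41 log units; beyond the scatter), where the chain on the same aromatic carbon grew by one carbon. Within the data shown here, a further lengthening is therefore expected to move this assay in the same direction by a comparable amount, a 1.8-fold lower number from compound 2 to compound 3 (0.25 log units; within the scatter), though the acceptor that enters has no counterpart among the measured compounds. Compound 3 is estimated at 6000 nM, range 2000 nM to 20000 nM.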

Compound 3, half-maximal inhibitory concentration: 11600 nM
Compound 3: middle estimate off by 1.9-fold (0.29 log units), on the low side; the measured number falls inside the stated range.
By their numbers in this assay, from the lowest: compounds 2 and 3 (each within the scatter of the next); then compound 1.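

In this assay, heptyloxy in place of pentyl on this aromatic carbon gives a 1.1-fold higher number from compound 2 to compound 3 (0.04 log units; within the scatter), so the drop seen with one added chain carbon does not continue to this larger group. Heptyloxy in place of butyl still gives a 2.3-fold lower number from compound 1 to compound 3 (0.37 log units; beyond the scatter), a modest step that leaves compound 3 level with compound 2 rather than ahead of it. Nothing available explains this result.

Open, on these data alone, is whether the oxygen or the chain length governs the result, which heptyl or butoxy at this position would separate. Also open, as far as these compounds go, is how an amine or a carboxylic acid at the chain end would read.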